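Moving the Chlorine on a Benzyl Group

The source may hold more compounds than are shown below. What is called first, only, known or untested is meant among the compounds shown, and "the series" means these compounds.

Compound 1 `COc1ccc(C2N=C(SCc3ccccc3Cl)NC(C)=C2C(=O)Nc2ccc(Br)cc2)cc1` and compound 2 `COc1ccc(C2N=C(SCc3cccc(Cl)c3)NC(C)=C2C(=O)Nc2ccc(Br)cc2)cc1` share one core and differ only in which chlorophenyl group sits on a saturated chain carbon bound to a sulfur. Both were tested in a functional assay on the whole organism (artery, strain albino) with Rattus norvegicus as the target, with a stated time of 30 min, at a dose of 10 mg/kg by the oral route; a lower number here means less inhibition, a higher number more inhibition at the dose given (going by the name of the read-out). In this assay compound 1 gives 4.6%, and in the same test compound 2 gives 7.7%. The step of a number 3.1 percentage points higher from compound 1 to compound 2 (within the scatter) is within the scatter, so these two numbers cannot be told apart. Compound 2 holds the higher of the two numbers, with compound 1 nearest, but that gap has no weight.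

Compound 3 `COc1ccc(C2N=C(SCc3ccc(Cl)cc3)NC(C)=C2C(=O)Nc2ccc(Br)cc2)cc1` has not yet been measured. It differs from compound 2 by 4-chlorophenyl in place of 3-chlorophenyl on a saturated chain carbon bound to a sulfur. Within the data shown here, the only measured step that bears on this change is a number 3.1 percentage points higher from compound 1 to compound 2 (within the scatter), and it stayed within the scatter: a change of the chlorophenyl group at this place, in the one case seen, did nothing that could be measured. The expected step of a number 0.7 percentage points lower from compound 2 to compound 3 (within the scatter) is therefore none beyond the scatter. Compound 3 is estimated at 7%, with a range from -5% to 20%, the width reflecting how little two low numbers can pin down.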

Compound 3, a percentage reported as inhibition, in the whole organism at one dose (the size of the read-out at that dose, not a potency): 7.2%
For compound 3 the middle estimate is 0.2 percentage points below the measured one; low and high end bracket the measured number.
By their numbers in this assay, from the lowest: compounds 1, 3 and 2 (each within the scatter of the next).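

With compound 3, all three chlorophenyl groups have been tested at this place, on a saturated chain carbon bound to a sulfur, so the position of the chlorine can now be judged across a full set in this assay. Among these compounds, the change to 4-chlorophenyl gives a number 0.5 percentage points lower from compound 2 to compound 3 (within the scatter), and the comparison with the 2-chlorophenyl compound gives a number 2.6 percentage points higher from compound 1 to compound 3 (within the scatter), so, together with the earlier step, no pair among the three can be told apart, and moving the chlorine around this ring has no measurable effect at this dose. Nothing measured here offers a reason for this flat result.

Going by these compounds, all three compounds carry a chlorine on the benzyl group, so it remains open whether the number would move if an amine or a carboxylic acid took the place of that chlorine, or if a longer chain replaced the benzyl group on the sulfur. On these data alone, whether changes elsewhere on the shared core would have a larger effect in this test also remains open.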